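The source may report more compounds than this note shows. Statements on the series, on what has been measured and on what is new or still open speak of the compounds shown alone.

Series notes. In a functional assay on the whole organism with Mus musculus as the target (on this read-out higher numbers stand for an effect only at larger amounts of compound and lower numbers for an effect already at smaller amounts), compound 1 `Cc1c(N)c(C)c2c(c1CC(C)C)OC(C)(C)C2` gives 13.3 mg/kg. Compound 2 `Cc1c(C)c2c(c(C)c1N)CC(C)(CSc1ccccc1)O2` gives 24.7 mg/kg in this assay, and compound 3 `Cc1c(C)c2c(c(C)c1N)CC(C)(CSc1nc3ccccc3s1)O2` gives 33.7 mg/kg. Among the three numbers compound 2 stands second highest; the nearest is that of compound 3 and the furthest that of compound 1, and both gaps lie within the scatter of repeated runs, so no order among these compounds is claimed. Compound 4 `Cc1c(C)c2c(c(C)c1N)CC(C)(CBr)O2` has not been measured. Relative to compound 2 it carries bromo in place of phenylsulfanyl on a saturated chain carbon bound to a saturated ring carbon. Among the compounds with values here, no measured pair shows what such a change does in this assay, and nothing in the three numbers points either way, so the step expected here, a 1.1-fold lower number from compound 2 to compound 4 (0.05 log units; within the scatter), is none beyond the scatter. Compound 4 is therefore expected to give about 22 mg/kg in this assay, with a range from 8 mg/kg to 55 mg/kg.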

Compound 4, dose for 50% inhibition: 16 mg/kg
Compound 4: the middle estimate sits 1.4-fold (0.14 log units) above what was measured; measured number inside the range.
By their numbers in this assay, from the lowest: compounds 1, 4, 2 and 3 (each within the scatter of the next, the first and the last beyond it).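

In this assay, within the data shown here, the first one-place pair at this saturated chain carbon bound to a saturated ring carbon gives a 1.5-fold lower number from compound 2 to compound 4 (0.19 log units; within the scatter) for bromo in place of phenylsulfanyl. The aromatic ring of the phenylsulfanyl group can therefore be removed from this position without a change that can be read beyond the scatter. Nothing at hand bears on the reason for this outcome. Going by these compounds, whether an amine, a hydroxyl or a carboxylic acid at this carbon would also stay within the scatter remains open. So does the effect of a longer chain carrying the bromo group.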